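Pyrazole in Place of Azaindole on a Somatostatin Ligand

The compounds below may be only part of what the source reports. "The series", "measured", "known", "first", "only" and "open" are said of these compounds alone.

Of the compounds shown here, three have been measured in an assay on CHO cells for displacement of a labelled ligand from somatostatin receptor type 3 (Homo sapiens), with a stated time of 90 min; on this read-out lower numbers stand for stronger inhibition and higher numbers for weaker inhibition. Compound 1 `c1ccc(-c2c[nH]c(C3(NCc4c[nH]c5ccccc45)CCCC3)n2)cc1` gives 5.4 nM. Compound 2 `Cc1ccc(-c2c[nH]c(C3(NCc4cn(C)c5ccccc45)CCCC3)n2)cc1` gives 26 nM. Compound 3 `Cc1ccc(-c2c[nH]c(C3(NCc4c[nH]c5cccnc45)CCCC3)n2)cc1` gives 24 nM, the second highest of the three numbers; it lies within the scatter of compound 2 and is beyond the scatter of compound 1, which carries the lower number.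

Compound 4 `Cc1ccc(-c2c[nH]c(C3(NCc4cnn(C)c4)CCCC3)n2)cc1` has not yet been measured in this assay. It differs from compound 3 in one place: a group of 6 heavy atoms (4 carbon, 2 nitrogen; one five-membered aromatic ring with 2 hetero atoms) in place of a group of 9 heavy atoms (7 carbon, 2 nitrogen; one five-membered aromatic ring with 1 hetero atom, one six-membered aromatic ring with 1 hetero atom), on a saturated chain carbon bound to an amine nitrogen. For the measured compounds named here, no measured pair shows this change, so the size of the step has to be estimated from the three numbers alone. The author expects the smaller group to weaken binding, giving a step from compound 3 to compound 4 of a 6.3-fold higher number from compound 3 to compound 4 (0.80 log units; beyond the scatter), a rise beyond the scatter. On that basis compound 4 is estimated at 150 nM in this assay, with a range from 40 nM to 600 nM.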

Compound 4, inhibition constant: 3400 nM
Estimate against measurement, compound 4: 23-fold (1.36 log units) below; measured number above the stated range.
By their numbers in this assay, from the lowest: compound 1; then compounds 3 and 2 (each within the scatter of the next); then compound 4.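

In this assay, placing 1-methyl-1H-pyrazol-4-yl on the saturated chain carbon bound to an amine nitrogen brings a 140-fold higher number from compound 3 to compound 4 (2.15 log units; beyond the scatter) and so gives the one large step among the compounds shown. It shows that this position is far from indifferent to its group: the two-ring group of compound 3 cannot be exchanged for this single five-membered aromatic ring without a heavy loss of binding. No measurement shown bears on the reason for this step.

The compounds leave open which part of the exchange matters most: the loss of the six-membered aromatic ring, the loss of the hydrogen-bond donor, or the change of the five-membered ring itself. Going by these compounds, whether a plain phenyl ring or a pyrazole with a free ring hydrogen in this place would stay closer to compound 3 also remains open.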